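The source may report more compounds than this note shows. Statements on the series, on what has been measured and on what is new or still open speak of the compounds shown alone.

Measured compounds in a functional assay on the whole organism (strain CF-1) for inhibition, with Mus musculus as the target; a higher number here means that more compound is needed for the effect, a lower number that less compound is needed:
- compound 1, `Cc1nnc(CN2CCCC2)n1-c1ccc(Cl)cc1C(=O)c1ccccc1`, gives 0.4 mg/kg.
- compound 2, `Cc1nnc(CN(C)C)n1-c1ccccc1C(=O)c1ccccc1Cl`, gives 5 mg/kg.
- compound 3, `CCNCc1nnc(C)n1-c1ccc(Cl)cc1C(=O)c1ccccc1`, gives 0.2 mg/kg.

Compound 2 stands highest of the three numbers in this assay; compound 1 and compound 3 both lie beyond the scatter below it, and the step of a 2.0-fold lower number from compound 1 to compound 3 (0.30 log units; within the scatter) between those two is within the scatter, so the amine on the chain carbon makes little difference on these data.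

Compound 4, `Cc1nnc(CN(C)C)n1-c1ccc(Cl)cc1C(=O)c1ccccc1Cl`, differs from compound 2 by chloro in place of hydrogen on an aromatic carbon, the entering group sitting para to a large group. Among the compounds with values here, no measured step covers this change in one place. Compound 1 and compound 3 both carry chloro on that ring and both give the low numbers above, but each also differs from compound 2 in the amine and in the chloro on the benzoyl ring, so the share belonging to the ring chloro alone cannot be separated. Taken together, the two low numbers point toward a lower number for compound 4, beyond the scatter. The step of an 8.3-fold lower number from compound 2 to compound 4 (0.92 log units; beyond the scatter) is the expected outcome. Compound 4 is estimated at 0.6 mg/kg, within 0.15 mg/kg to 2.5 mg/kg.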

Compound 4, dose for half-maximal effect: 0.14 mg/kg
For compound 4 the middle estimate is 4.3-fold (0.63 log units) above the measured one; measured number outside the range, below it.
By their numbers in this assay, from the lowest: compounds 4, 3 and 1 (each within the scatter of the next, the first and the last beyond it); then compound 2.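

In this assay, chloro in place of hydrogen on the aromatic carbon para to a large group gives a 36-fold lower number from compound 2 to compound 4 (1.55 log units; beyond the scatter) as a single change, and this is large. The earlier compounds shown here carried this chloro only alongside other differences, whereas here the amine on the chain carbon and the chloro on the benzoyl ring stay the same, so the whole step belongs to this one position. No available measurement bears on why the step has this size.

Open, as far as these compounds go, is whether chloro at this position gives a step of similar size with the pyrrolidin-1-yl of compound 1, with the ethylamino of compound 3, or without the chloro on the benzoyl ring. Also open, from the compounds shown here alone, is how bromo, trifluoromethyl or nitro would compare with chloro at the same position.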